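This account rests on a few compounds, and the source may have more. Where it says the series, first, only, none or still open, it means among the compounds named here.

Compound 3 `Nc1sc(-c2ccccc2)c(-c2cccc(C(F)(F)F)c2)c1C(=O)c1ccccc1` was measured in an assay on CHO-K1 cells for displacement of a labelled ligand from adenosine receptor A1 (Homo sapiens), tested at 10 uM (a lower number here means less inhibition, a higher number more inhibition at the concentration tested (going by the name of the read-out)), where compound 3 gives 82.4%. Among the three measured compounds it stands second highest: compound 2 `CCOC(=O)c1c(-c2cccc(C(F)(F)F)c2)csc1N` gives 93%, a number above it beyond the scatter, while compound 1 `Nc1sc(Br)c(-c2cccc(C(F)(F)F)c2)c1C(=O)c1ccccc1` gives 47.5%, the furthest from it and lower beyond the scatter. Among the measured compounds shown here, the only single-point step recorded, a number 34.9 percentage points higher from compound 1 to compound 3 (beyond the scatter), concerns a different part of the shared core and does not bear on the change now in view. Compound 4 `CCOC(=O)c1c(N)sc(-c2ccccc2)c1-c1cccc(C(F)(F)F)c1` differs from compound 3 in one place: ethoxy in place of phenyl on a carbonyl carbon. For the measured compounds named here, no measured pair differs only by this change; compound 2 carries the ethoxycarbonyl and compound 3 the benzoyl, but they differ elsewhere as well, and their two values show only that compound 2 reads higher. Going by the values given here, with that as the sole guide, the expected step in this assay is a number 7.6 percentage points higher from compound 3 to compound 4 (within the scatter). The estimate for compound 4 is 90%, with a range from 75% to 99%.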

Compound 4, a percentage reported as inhibition, at one concentration (the size of the read-out at that concentration, not a potency): 83.6%
For compound 4 the middle estimate is 6.4 percentage points above the measured one; measured number inside the range.
By their numbers in this assay, from the lowest: compound 1; then compounds 3, 4 and 2 (each within the scatter of the next, the first and the last beyond it).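

In this assay, among the compounds shown here, the first direct reading of ethoxy in place of phenyl on a carbonyl carbon, the change from benzoyl to ethoxycarbonyl, is a number 1.2 percentage points higher from compound 3 to compound 4 (within the scatter) and so this read-out does not separate the two groups at this place, although the ethoxy carries no ring. With the ethoxycarbonyl kept, adding a phenyl to the shared core gives a number 9.4 percentage points lower from compound 2 to compound 4 (within the scatter) and so does not separate those two compounds either. Nothing on hand offers a reason for these readings.

From the compounds shown here alone, it remains open whether other groups on the carbonyl carbon, such as a carboxylic acid, an amine forming an amide or a longer chain ester, would read alike. A single concentration also leaves open whether compound 3 and compound 4 would match in potency.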